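This account rests on a few compounds, and the source may have more. Where it says the series, first, only, none or still open, it means among the compounds named here.

Compound 1 `O=C(C1CCN(c2ncccn2)CC1)N1N=CC[C@H]1c1ccccc1` — > 3.11 h
Compound 2 `N#Cc1ccc(N2CCC(C(=O)N3N=CC[C@H]3c3cc(F)cc(F)c3)CC2)nn1` — > 8 h
Compound 3 `Cc1nnc(N2CCC(C(=O)N3N=CC[C@H]3c3ccccc3)CC2)o1` — 3.3 h

Of the compounds shown here, three have been measured in an ADME assay on cells (Hepatocyte, Homo sapiens) for metabolic stability; a higher number here means that the compound lasts longer, a lower number that the compound disappears faster. Compound 1 gives > 3.11 h, which is a limit of the assay and not a number (the limit of > 3.11 h in this assay, at which 1 of the 3 values shown sits). Compound 3, carrying 5-methyl-1,3,4-oxadiazol-2-yl in place of pyrimidin-2-yl on an amine nitrogen in a ring, gives 3.3 h. The step that the limit leaves unreadable from compound 1 to compound 3 therefore cannot be read. Compound 2 gives > 8 h, again a limit of the assay (the limit of > 8 h in this assay, at which 1 of the 3 values shown sits). Compound 2 thus stands at the far end of what this assay can report, and its standing relative to the other two compounds cannot be ranked.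

Compound 4 `N#Cc1nccc(N2CCC(C(=O)N3N=CC[C@H]3c3cc(F)cc(F)c3)CC2)n1` is yet to be measured in this assay. It differs from compound 2 in one place: a group of 8 heavy atoms (5 carbon, 3 nitrogen; one six-membered aromatic ring with 2 hetero atoms) in place of a group of 8 heavy atoms (5 carbon, 3 nitrogen; one six-membered aromatic ring with 2 hetero atoms), on an amine nitrogen in a ring The two have the same atoms, joined differently. Among the compounds with values here, no measured step bears directly on this change; the only step recorded is the one from compound 1 to compound 3, and its size is unreadable. The account therefore expects no step beyond the scatter, with the reading again likely to reach the limit. Compound 4 is estimated at 8 h, with a range from 4 h to 16 h. The step expected is a number no higher from compound 2 to compound 4 (the limit leaves the size open).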

Compound 4, half-life: 2.1 h
The estimate for compound 4 lay 3.8-fold (0.58 log units) above the measured number; the whole stated range lies above it.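

In this assay, 2-cyanopyrimidin-4-yl on an amine nitrogen in a ring, in place of a group of the same atoms joined differently, gives an at least 3.8-fold lower number from compound 2 to compound 4 (0.58 log units; beyond the scatter). At this position, then, the way these atoms are joined can alone carry a change beyond the scatter, with the counts of heavy atoms, hydrogen-bond donors and hydrogen-bond acceptors all the same in the two groups, although nothing shown tells why the number falls. Compound 2 gives a limit of the assay and not a number, so the step has a floor and no known full size: the limit of > 8 h in this assay, at which 1 of the 4 values shown sits.

Still open, on these data alone, is how a methoxy group or an amine in place of the nitrile on the pyrimidine ring would read in this assay, and so whether the fall depends on the nitrile at this place in the ring. Within the data shown here, also open is whether the same exchange would give a similar step on the core of compound 3, since the one earlier step between different groups at this position cannot be read.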